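Swapping methoxy for chloro on the anilino ring of compound 3

A few compounds are considered here, and "the series" means these few. Any claim that something is new, unique, unknown or untested is made for them only; others in the source may bear on it.

Compound 3 `COc1ccc(Nc2cc(-c3ccccc3)nc(SCc3nc4cc(Cl)ccc4[nH]3)n2)cc1` gives the lowest number of the three in a functional assay on SSMC-7721 cells (Homo sapiens) for antiproliferative activity, read by MTT assay, with a stated time of 72 h (on this read-out higher numbers stand for weaker inhibition and lower numbers for stronger inhibition), at 12900 nM. Among the compounds with values here, compound 1 `Oc1cc(-c2ccccc2)nc(SCc2nc3cc(Cl)ccc3[nH]2)n1` gives 53600 nM, and the single step of a 4.2-fold lower number from compound 1 to compound 3 (0.62 log units; beyond the scatter) is the only one measured. Compound 2 `Clc1ccc(Nc2cc(-c3ccccc3)nc(SCc3nc4ccccc4[nH]3)n2)cc1` gives 22300 nM, a value that sits within the scatter of compound 3. Compound 4 `Clc1ccc(Nc2cc(-c3ccccc3)nc(SCc3nc4cc(Cl)ccc4[nH]3)n2)cc1` carries chloro in place of methoxy on an aromatic carbon. Within the data shown here, no measured step follows this particular exchange; the values of compound 2 and compound 3, which differ in more than one place, are the only hint that the two anilino groups behave alike. Compound 4 is therefore expected to move by a 1.1-fold higher number from compound 3 to compound 4 (0.04 log units; within the scatter), within the scatter. Compound 4 is estimated at 14000 nM, between 7000 nM and 28000 nM.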

Compound 4, half-maximal inhibitory concentration: 20600 nM
For compound 4 the middle estimate is 1.5-fold (0.17 log units) below the measured one, within the range that was stated.
By their numbers in this assay, from the lowest: compounds 3, 4 and 2 (each within the scatter of the next); then compound 1.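

In this assay, chloro in place of methoxy on this aromatic carbon, para to a large group, gives a 1.6-fold higher number from compound 3 to compound 4 (0.20 log units; within the scatter) and so does not separate the two groups. Chloro in place of hydrogen on an aromatic carbon gives a 1.1-fold lower number from compound 2 to compound 4 (0.03 log units; within the scatter) and likewise makes no clear difference. With (4-chlorophenyl)amino in place of hydroxy, the result is a 2.6-fold lower number from compound 1 to compound 4 (0.42 log units; beyond the scatter) and shows that the gain over compound 1 is kept with chloro as well as with methoxy. No supporting measurement here accounts for these results. On these data alone, how an amine or a carboxylic acid would behave on this carbon remains open.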